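Trifluoromethyl in place of ethoxy on the shared core

The source may hold more compounds than are shown below. What is called first, only, known or untested is meant among the compounds shown, and "the series" means these compounds.

Measured compounds:
compound 1 `Cc1c(C(=O)Nc2c(F)cc(-c3cccc(F)c3)cc2F)nc2ccc(F)cc2c1O`: 16.2%
compound 2 `CCOc1ccc2nc(C(=O)Nc3c(F)cc(-c4cccc(F)c4)cc3F)c(C)c(O)c2c1`: 15.3%

In a functional assay on A-375 cells (Homo sapiens) for antiproliferative activity, read by MTT assay, with a stated time of 24 h, tested at 11.11 ug/mL (on this read-out higher numbers stand for a stronger effect at the one concentration tested and lower numbers for a weaker effect), compound 1 gives 16.2% and compound 2 gives 15.3%. Compound 2 holds the lower of the two numbers, yet its nearest neighbour, compound 1, lies within the scatter of it, so no order between them can be read. Going by the values given here, the single step known so far, a number 0.9 percentage points lower from compound 1 to compound 2 (within the scatter), exchanged one substituent on an aromatic carbon of the same fused system without moving the number beyond the scatter.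

Compound 3 `Cc1c(C(=O)Nc2c(F)cc(-c3cccc(F)c3)cc2F)nc2ccc(C(F)(F)F)cc2c1O` continues from compound 2 by the change (trifluoromethyl in place of ethoxy on an aromatic carbon). Among the compounds with values here, the only step that bears on it is the one from compound 1 to compound 2, which was within the scatter; a second exchange at the same aromatic carbon is therefore expected to give no step beyond the scatter in this assay, that is a number 0.3 percentage points lower from compound 2 to compound 3 (within the scatter). Compound 3 is accordingly expected to show about 15%, between 5% and 28%.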

Compound 3, a percentage reported as inhibition, at one concentration (the size of the read-out at that concentration, not a potency): 46.3%
Estimate against measurement, compound 3: 31.3 percentage points below; measured number above the stated range.
By their numbers in this assay, from the lowest: compounds 2 and 1 (each within the scatter of the next); then compound 3.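

In this assay, this aromatic carbon turns out to be a place where the substituent can matter: trifluoromethyl in place of ethoxy gives a number 31 percentage points higher from compound 2 to compound 3 (beyond the scatter), and trifluoromethyl in place of fluoro gives a number 30.1 percentage points higher from compound 1 to compound 3 (beyond the scatter). The earlier exchange of fluoro for ethoxy had shown no separation, so among the three groups shown on the shared core, only trifluoromethyl stands apart from the others. Nothing available explains why this group differs from the other two.

The compounds shown leave open whether the higher number is particular to trifluoromethyl or would also appear with a nitrile, a carboxylic acid, an amine or a longer chain on this carbon. They also leave open how this difference at a single concentration would translate into potency.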